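The source may hold more compounds than are shown below. What is called first, only, known or untested is meant among the compounds shown, and "the series" means these compounds.

Of the compounds shown here, two have been tested in a functional assay on RBL cells for antagonist activity at C-X-C chemokine receptor type 1 (Homo sapiens), read by fluorescence and calcium flux, with a stated time of 30 min; on this read-out higher numbers stand for weaker inhibition and lower numbers for stronger inhibition. Compound 1 `O=C(Nc1ccc(F)cc1)c1cnc(N(Cc2ccccc2)Cc2ccc(B(O)O)cn2)nc1` gives 7 nM, while compound 2 `O=C(Nc1ccc(F)cc1)c1ccc(NCc2cccc(B(O)O)c2)nc1` gives 611 nM, the higher of the two numbers, so compound 2 is the weaker inhibitor of the pair, and the gap between them lies beyond the usual scatter. Compound 3 `CN(Cc1cccc(B(O)O)c1)c1ccc(C(=O)Nc2ccc(F)cc2)cn1` is made from compound 2 by one change: methyl in place of hydrogen on a nitrogen on an aromatic ring. For the measured compounds named here, no measured pair shows this exact change. Since compound 1, which carries a substituted nitrogen at a similar spot, gives 7 nM, a modest move towards stronger inhibition is expected, as a 2.4-fold lower number from compound 2 to compound 3 (0.39 log units; beyond the scatter). Compound 3 is therefore estimated at 250 nM, with a range from 60 nM to 1000 nM.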

Compound 3, half-maximal inhibitory concentration: 4100 nM
Compound 3: the middle estimate sits 16-fold (1.21 log units) below what was measured, and the stated range ends below it.
By their numbers in this assay, from the lowest: compound 1; then compound 2; then compound 3.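

In this assay, this nitrogen proves sensitive to a very small change: methyl in place of hydrogen gives a 6.7-fold higher number from compound 2 to compound 3 (0.83 log units; beyond the scatter), so inhibition weakens rather than strengthens. One added carbon on this nitrogen is therefore enough to cost activity on this core. Nothing measured here explains the loss. Going by these compounds, whether an ethyl group or a longer chain on this nitrogen would behave like methyl remains open. So does whether methyl would have the same effect on the core of compound 1.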